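Cytotoxicity series: methoxycarbonyl on the piperidine ring

A few compounds are considered here, and "the series" means these few. Any claim that something is new, unique, unknown or untested is made for them only; others in the source may bear on it.

Measured compounds in an ADME assay on HepG2 cells (Homo sapiens) for cytotoxicity, with a stated time of 72 h; a higher number here means that more compound is needed for the effect, a lower number that less compound is needed:
compound 1 `O=C(Nc1nc(-c2ccc(Cl)cc2)cs1)c1cc([N+](=O)[O-])ccc1Cl`: > 27000 nM, a limit of the assay.
compound 2 `Cc1ccc(-c2nc3ccccc3s2)cc1NC(=O)c1cc([N+](=O)[O-])c(N2CCCCC2)cc1Cl`: > 25000 nM, a limit of the assay.
compound 3 `Cc1cc(NC(=O)c2cc([N+](=O)[O-])ccc2Cl)cc(-c2nc3ccccc3o2)c1O`: > 25000 nM, a limit of the assay.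

Compound 2 stands at a limit only, and no number sets it apart from the others; it sits at the limit of > 25000 nM in this assay, at which 2 of the 3 values shown sit, while compound 1 sits at the limit of > 27000 nM in this assay, at which 1 of the 3 values shown sits. Compound 4 `COC(=O)C1CCN(c2cc(Cl)c(C(=O)Nc3cc(-c4nc5ccccc5s4)ccc3C)cc2[N+](=O)[O-])CC1` is not yet measured. It differs from compound 2 by methoxycarbonyl in place of hydrogen on a saturated ring carbon, read one bond further out as piperidin-1-yl to 4-(methoxycarbonyl)piperidin-1-yl. Within the data shown here, with every value shown a limit, no step between measured compounds exists; none beyond the scatter is expected here. The step that the limit leaves unreadable from compound 2 to compound 4 is expected to stay within the scatter. Compound 4 is expected at 30000 nM, between 10000 nM and 100000 nM, most likely again reported as a limit.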

Compound 4, half-maximal effective concentration: > 25000 nM
Compound 4 ended at the assay's limit (the forecaster's own chance of this, stated with the estimate: 80%); the middle value is on the limit's open side.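

In this assay compound 2 gives > 25000 nM, a limit of the assay. Among these compounds, compound 4 gives > 25000 nM, also a limit, and no step between compound 2 and compound 4 can be read. As far as these compounds go, whether methoxycarbonyl in place of hydrogen changes the value in this assay at all stays open.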